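The source may hold more compounds than are shown below. What is called first, only, known or untested is meant among the compounds shown, and "the series" means these compounds.

Three compounds have so far been measured in a functional assay on the whole organism (Tail, strain ICR) with Mus musculus as the target, in the tail flick test, with a stated time of 30 min, at a dose of 25 umol/kg by the oral route; a higher number here means a stronger effect of the compound at the dose given, a lower number a weaker effect:

compound 1 `O=C(CN(c1ncnc2c1ncn2C1CCCCO1)C1CC1)N[C@@H](CO)C(=O)OCc1ccccc1`, giving 27.8%
compound 2 `NCCCC[C@H](NC(=O)CN(c1nc(Cl)nc2[nH]cnc12)C1CC1)C(=O)OCc1ccccc1`, giving 26.1%
compound 3 `NC(=O)CC[C@H](NC(=O)CN(c1nc(Cl)nc2[nH]cnc12)C1CC1)C(=O)O`, giving 33.1%

Compound 2 sits at the low end of these three numbers, yet its gap to compound 1 and its gap to compound 3 both lie within the usual scatter of repeated measurements, so the three values cannot be told apart. Compound 4 `NC(=O)C[C@H](NC(=O)CN(c1nc(Cl)nc2[nH]cnc12)C1CC1)C(=O)OCc1ccccc1` has not yet been measured. It differs from compound 2 in one place: carbamoyl in place of 3-aminopropyl on a saturated chain carbon, two bonds along the chain from an amide-type nitrogen and a carbonyl carbon. Among the compounds with values here, no pair of measured compounds differing in a single place is available, so there is no measured step to lean on. Since compound 1, compound 2 and compound 3 all fall within scatter of one another despite their different chains and ester groups, the change to compound 4 is expected to give no step beyond the scatter in this assay, in either direction. Compound 4 is therefore expected to come out at about 29%, in the range 15% to 45%. This estimate means a step from compound 2 to compound 4 of a number 2.9 percentage points higher from compound 2 to compound 4 (within the scatter), which is expected to stay within the scatter.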

Compound 4, a percentage reported as activity, at one dose (the size of the read-out at that dose, not a potency): 24.4%
Estimate against measurement, compound 4: 4.6 percentage points above; the measured number falls inside the stated range.
By their numbers in this assay, from the lowest: compounds 4, 2, 1 and 3 (each within the scatter of the next).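

In this assay, the series now has its first comparison of compounds that differ in one place: carbamoyl in place of 3-aminopropyl on a saturated chain carbon, two bonds along the chain from an amide-type nitrogen and a carbonyl carbon, gives a number 1.7 percentage points lower from compound 2 to compound 4 (within the scatter) at the dose tested. At this position, the terminal amine of the 3-aminopropyl group can therefore be exchanged for carbamoyl with no step that can be told from the scatter, so the amine is not shown to be needed for the effect read here. No available data explain this result.

As far as these compounds go, whether a carboxylic acid or a longer chain on this carbon would give a step beyond the scatter remains open. Also open, from the compounds shown here alone, is whether this same change would stay within the scatter at another dose.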